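This account rests on a few compounds, and the source may have more. Where it says the series, first, only, none or still open, it means among the compounds named here.

Compound 1 `Nc1ccccc1NC(=O)c1ccc(CSC(=S)N2CCN(c3ccccc3)CC2)cc1` carries a phenyl on an amine nitrogen in a ring at the thiocarbonyl end of the shared core. Among the compounds with values here, in a functional assay on HeLa cells (Homo sapiens) for antiproliferative activity, read by CCK-8 assay, with a stated time of 72 h, tested at 2 uM (a lower number here means a weaker effect, a higher number a stronger effect of the compound at the concentration tested), compound 1 gives 62.2%, the second highest of the three numbers measured so far. Compound 3 `CCN(Cc1ccncc1)C(=S)SCc1ccc(C(=O)Nc2ccccc2N)cc1` gives 63.5% in this assay, which lies within the scatter of compound 1. Compound 2 `CC1CCCCN1C(=S)SCc1ccc(C(=O)Nc2ccccc2N)cc1` gives 45.5% in this assay, a number beyond the scatter lower than that of compound 1. Within the data shown here, the one step measured between neighbours, a number 18 percentage points higher from compound 2 to compound 3 (beyond the scatter), replaces the whole amine on the thiocarbonyl carbon.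

Compound 4 `Nc1ccccc1NC(=O)c1ccc(CSC(=S)N2CCN(c3cnccn3)CC2)cc1` has not yet been measured. (pyrazin-2-yl in place of phenyl on an amine nitrogen in a ring). The measured step bears only indirectly on this change: from compound 2 to compound 3 the amine on the thiocarbonyl carbon itself was exchanged, whereas from compound 1 to compound 4 that ring amine is kept and only the aryl group on its second nitrogen changes. Among the measured compounds shown here, no measured pair exchanges an aryl group at that position. The expectation in this assay is therefore a step of no size beyond the scatter, in either direction. Compound 4 is estimated at 58%, with a range from 40% to 75%. The step of a number 4.2 percentage points lower from compound 1 to compound 4 (within the scatter) that this estimate means is expected to stay within the scatter.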

Compound 4, a percentage reported as inhibition, at one concentration (the size of the read-out at that concentration, not a potency): 70.4%
Compound 4: middle estimate off by 12.4 percentage points, on the low side; low and high end bracket the measured number.
By their numbers in this assay, from the lowest: compound 2; then compounds 1, 3 and 4 (each within the scatter of the next).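

In this assay, within the data shown here, the first measured exchange of the aryl group on the ring amine nitrogen, a number 8.2 percentage points higher from compound 1 to compound 4 (within the scatter), leaves compound 1 and compound 4 indistinguishable, so this read-out does not separate phenyl from pyrazin-2-yl at this position. Among these compounds, the position therefore accepts a six-membered aromatic ring with 2 hetero atoms and 2 hydrogen-bond acceptors in place of a ring of carbon only without a fall beyond the scatter, although this rests on a single pair and contrasts with the exchange of the whole amine on the thiocarbonyl carbon, a number 18 percentage points higher from compound 2 to compound 3 (beyond the scatter), the only step beyond the scatter. Nothing available accounts for the result at compound 4 or says what the exchanged ring atoms do here.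

Open, as far as these compounds go, is whether a pyridin-2-yl, a benzyl or an acetyl on the same nitrogen would also stay within the scatter of compound 1, or whether a bare methyl there would give a step beyond it. From the compounds shown here alone, since each read-out comes from one concentration, the potency of compound 1 and compound 4 also remains open.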